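This account rests on a few compounds, and the source may have more. Where it says the series, first, only, none or still open, it means among the compounds named here.

Measured so far in a functional assay on 786-0 cells (Homo sapiens) for cytotoxicity, read by sulforhodamine B assay, with a stated time of 48 h; on this read-out lower numbers stand for stronger inhibition of growth and higher numbers for weaker inhibition of growth
Compound 1 (`Nc1c(C(=O)Nc2ccccc2)sc2nc3c(cc12)CCCCCC3`) gives 354 nM
Compound 2 (`Nc1c(C(=O)Nc2ccccc2Cl)sc2nc3c(cc12)CCCCCC3`) gives 1750 nM

Of these two, compound 1 has the lower number and so the stronger inhibition of growth. Compound 3 (`Nc1c(C(=O)Nc2cccc(C(F)(F)F)c2)sc2nc3c(cc12)CCCCCC3`) has not yet been measured. It differs from compound 1 in one place (trifluoromethyl in place of hydrogen on an aromatic carbon): trifluoromethyl in place of hydrogen on an aromatic carbon, meta to a large group.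

Within the data shown here, only one measured step bears on this change. Chloro in place of hydrogen on an aromatic carbon gave a 4.9-fold higher number from compound 1 to compound 2 (0.69 log units; beyond the scatter) in this assay, a modest step. That is thin evidence, as it is a single step and a different group enters in compound 3. The expected change therefore points the same way, towards weaker inhibition, but is estimated to be smaller (a 2.0-fold higher number from compound 1 to compound 3 (0.30 log units; within the scatter)), and it may even stay within the scatter. For compound 3 the estimated value is 700 nM, with an expected range from 200 nM to 2500 nM as the limits of that estimate.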

Compound 3, concentration for 50% growth inhibition: 1600 nM
Estimate against measurement, compound 3: 2.3-fold (0.36 log units) below; the range from low to high includes it.
By their numbers in this assay, from the lowest: compound 1; then compounds 3 and 2 (each within the scatter of the next).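

In this assay, the rise in the number is not confined to chloro: a 4.5-fold higher number from compound 1 to compound 3 (0.66 log units; beyond the scatter), so trifluoromethyl on an aromatic carbon, meta to a large group, also weakens inhibition of growth by a margin beyond the scatter. Compound 1, which carries only hydrogen on that ring, keeps the lowest number of the three, so both substituted compounds shown lie on the weaker side of it. No accompanying measurement gives any reason for this loss of activity.

Compounds 2 and 3 differ from each other in more than one place, so these data cannot separate the effect of the group that enters from the effect of where it sits on the ring. On these data alone, it remains open whether trifluoromethyl would give a similar step on another carbon of that ring, and whether an amine or a methoxy group on the same carbon would keep the number near that of compound 1 or lower it.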